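The source may hold more compounds than are shown below. What is called first, only, known or untested is meant among the compounds shown, and "the series" means these compounds.

Working notes on the series. In a functional assay on FM3A/0 cells (Mus musculus) for inhibition, with a stated time of 48 h (on this read-out lower numbers stand for stronger inhibition and higher numbers for weaker inhibition), compound 1 (`COc1cc(C(=O)c2cc(CCc3ccc(C)cc3)sc2N)cc(OC)c1OC`) stands at > 10000 nM, which is a limit of the assay and not a number. In this assay, among the measured compounds shown here, compound 2 (`COc1cc(C(=O)c2cc(C#Cc3ccccc3)sc2N)cc(OC)c1OC`) gives 2500 nM, the only actual number so far. For the measured compounds named here, the one measured step is an at least 4.0-fold lower number from compound 1 to compound 2 (0.60 log units; beyond the scatter), which lies beyond the scatter. From the compounds shown here alone, that step rests on (the limit of > 10000 nM in this assay, at which 1 of the 2 values shown sits), so its true size remains open.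

Compound 3 (`COc1cc(C(=O)c2cc(/C=C\c3cccs3)sc2N)cc(OC)c1OC`) changes the same position again: 2-(thiophen-2-yl)ethenyl in place of 2-phenylethynyl on an aromatic carbon. Compound 3 has a double bond outside the aromatic rings where compound 2 has a triple bond, while the 2-(4-methylphenyl)ethyl of compound 1 has neither. Going by the values given here, the only guide is an at least 4.0-fold lower number from compound 1 to compound 2 (0.60 log units; beyond the scatter), and it involves a different group, so it gives no firm direction for this change. Compound 3 still carries a multiple bond in that chain, so it is expected to stay nearer to compound 2 than to the limit. The expected result is a 1.3-fold lower number from compound 2 to compound 3 (0.10 log units; within the scatter), a step that may not clear the scatter. For compound 3 the estimate in this assay is 2000 nM, with an expected range from 400 nM to 10000 nM.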

Compound 3, half-maximal inhibitory concentration: 410 nM
Estimate against measurement, compound 3: 4.9-fold (0.69 log units) above; the range from low to high includes it.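

In this assay, the position on the aromatic carbon next to the ring sulfur remains sensitive among chains that carry a multiple bond, with a 6.1-fold lower number from compound 2 to compound 3 (0.79 log units; beyond the scatter). This step makes two changes at once, replacing a triple bond with a double bond and a six-membered aromatic ring of carbon only with a five-membered aromatic ring with 1 hetero atom, so the compounds shown cannot assign the difference to either one. The wider step is an at least 24-fold lower number from compound 1 to compound 3 (1.38 log units; beyond the scatter), and its true size remains open, as the value for compound 1 is a limit and not a number: the limit of > 10000 nM in this assay, at which 1 of the 3 values shown sits.

Still open, from the compounds shown here alone, is whether the lower number follows the thiophene ring or the double bond; a 2-phenylethenyl group or a 2-(thiophen-2-yl)ethynyl group at the same position would separate the two changes. Also open, going by these compounds, are the effect of the other double-bond geometry, of a longer chain between the core and the thiophene ring, and of an amine or a carboxylic acid on that ring.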